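The source may report more compounds than this note shows. Statements on the series, on what has been measured and on what is new or still open speak of the compounds shown alone.

Measured in an assay on isolated protein for inhibition of histone deacetylase 4 (Homo sapiens), with a stated time of 1 h; a higher number here means a weaker inhibitor, a lower number a stronger inhibitor:
compound 1 `O=C(COc1ccc2cc(/C=C3/SC(=O)NC3=O)ccc2c1)Nc1cc(Cl)cc(C(F)(F)F)c1` gives 4000 nM;
compound 2 `COc1cccc(NC(=O)COc2ccc3cc(/C=C4/SC(=O)NC4=O)ccc3c2)c1` gives 1600 nM;
compound 3 `Cc1cc(NC(=O)COc2ccc3cc(/C=C4/SC(=O)NC4=O)ccc3c2)no1` gives 1700 nM.

Compound 1 stands highest of these three numbers, so it is the weakest inhibitor measured. Its nearest neighbour is compound 3 a 2.4-fold lower number from compound 1 to compound 3 (0.37 log units; beyond the scatter), and its furthest is compound 2 a 2.5-fold lower number from compound 1 to compound 2 (0.40 log units; beyond the scatter). Compound 4 `O=C(COc1ccc2cc(/C=C3/SC(=O)NC3=O)ccc2c1)Nc1cccc(F)n1` differs from compound 1 in one place: 6-fluoropyridin-2-yl in place of 3-chloro-5-(trifluoromethyl)phenyl on an amide-type nitrogen. Going by the values given here, two measured steps bear on this change, since both also swap out the 3-chloro-5-(trifluoromethyl)phenyl for a smaller aromatic group: a 2.5-fold lower number from compound 1 to compound 2 (0.40 log units; beyond the scatter) and a 2.4-fold lower number from compound 1 to compound 3 (0.37 log units; beyond the scatter). Those two replacements are indistinguishable from each other a 1.1-fold higher number from compound 2 to compound 3 (0.03 log units; within the scatter). A modest step to a lower number is therefore expected in this assay, a 2.2-fold lower number from compound 1 to compound 4 (0.35 log units; beyond the scatter). Compound 4 is estimated at 1800 nM, with a range from 800 nM to 4000 nM.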

Compound 4, half-maximal inhibitory concentration: 840 nM
The estimate for compound 4 lay 2.1-fold (0.33 log units) above the measured number, and the stated range covers the measured number.
By their numbers in this assay, from the lowest: compounds 4, 2 and 3 (each within the scatter of the next, the first and the last beyond it); then compound 1.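

Swapping 3-chloro-5-(trifluoromethyl)phenyl for 6-fluoropyridin-2-yl on this amide-type nitrogen again lowers the number (a 4.8-fold lower number from compound 1 to compound 4 (0.68 log units; beyond the scatter)). The replacement groups now begin to separate from one another (a 2.0-fold lower number from compound 3 to compound 4 (0.31 log units; beyond the scatter)), although the gap to the 3-methoxyphenyl group stays within the scatter (a 1.9-fold lower number from compound 2 to compound 4 (0.28 log units; within the scatter)). No measurement here explains these differences. The compounds shown cannot tell whether the ring nitrogen or the fluorine matters more, which plain pyridin-2-yl would help separate. From the compounds shown here alone, how an amine or a carboxylic acid on this ring would fare also remains open.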